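This account rests on a few compounds, and the source may have more. Where it says the series, first, only, none or still open, it means among the compounds named here.

Three compounds have been measured in a functional assay, read by spectrophotometry, with a stated time of 15 min, tested at 80 ug/mL; a lower number here means a weaker effect, a higher number a stronger effect of the compound at the concentration tested:

compound 1, `Fc1ccc(-c2csc(N/N=C/c3cccs3)n2)cc1`, giving 91.9%;
compound 2, `Clc1ccc(/C=N/Nc2nc(-c3ccccc3)cs2)c(Cl)c1`, giving 83.1%;
compound 3, `Clc1ccc(-c2csc(N/N=C/c3cccs3)n2)cc1`, giving 86%.

Compound 2 sits at the low end of these three numbers. Its nearest neighbour is compound 3, its furthest is compound 1, and neither gap reaches beyond the usual scatter of this kind of measurement, so no order among the three can be claimed. Among the compounds with values here, the only step measured between two compounds that differ in one place runs from compound 1 to compound 3, a number 5.9 percentage points lower from compound 1 to compound 3 (within the scatter), and that step concerns a halogen swap on the aromatic ring.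

Compound 4, `COc1ccc(-c2csc(N/N=C/c3ccc(Cl)cc3Cl)n2)cc1`, has not yet been measured. It differs from compound 2 as follows: methoxy in place of hydrogen on an aromatic carbon. No measured step concerns a methoxy group, so nothing in the shown data speaks to this change directly. Within the data shown here, the one comparable step, from compound 1 to compound 3, stayed within the scatter, and the three measured numbers lie close together. Compound 4 is therefore expected to give 83%, with a range from 70% to 93%. The step from compound 2 to compound 4 that this estimate means, a number 0.1 percentage points lower from compound 2 to compound 4 (within the scatter), is expected to stay within the scatter.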

Compound 4, a percentage reported as inhibition, at one concentration (the size of the read-out at that concentration, not a potency): 84.2%
The estimate for compound 4 lay 1.2 percentage points below the measured number; the range from low to high includes it.
By their numbers in this assay, from the lowest: compounds 2, 4, 3 and 1 (each within the scatter of the next).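

In this assay, putting methoxy in place of hydrogen, on an aromatic carbon para to a large group, gave a number 1.1 percentage points higher from compound 2 to compound 4 (within the scatter), so compound 2 and compound 4 cannot be told apart at the one concentration tested. The earlier step compared only one halogen with another, whereas this one turns phenyl into 4-methoxyphenyl, adding 2 heavy atoms and 1 hydrogen-bond acceptor at this place, and it shows that this addition comes with no difference beyond the scatter in this pair. Nothing shown offers an explanation for this result, and no measurement beyond the read-out itself bears on it.

The compounds shown leave open whether an amine, a carboxylic acid or a longer chain such as butoxy at this place would also stay within the scatter of compound 2, since only hydrogen and methoxy can be compared here with the rest of the structure held fixed. They also leave open whether methoxy would behave in the same way in the structure of compound 1 and compound 3, which differ from compound 4 in more than one place.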